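Swapping the amide for an ester on the anilino nitrogen

The compounds below may be only part of what the source reports. "The series", "measured", "known", "first", "only" and "open" are said of these compounds alone.

Three thioureas have been measured in an assay for inhibition of transient receptor potential cation channel subfamily V member 1 (Rattus norvegicus), with a stated time of 10 min; on this read-out higher numbers stand for weaker inhibition and lower numbers for stronger inhibition. Compound 1 `CS(=O)(=O)Nc1ccc(C/N=C(\S)NCc2ccccc2)cc1F` gives 9700 nM, and compound 2 `CC(C)(C)c1ccc(C/N=C(\S)NCc2ccc(NS(C)(=O)=O)c(I)c2)cc1` gives 41 nM. Compound 3 `COCC(=O)Nc1ccc(C/N=C(\S)NCc2ccc(C(C)(C)C)cc2)cc1F` gives 10900 nM, the highest of the three numbers; the number for compound 1 is within the scatter of it, while the number for compound 2 lies far lower, a difference well beyond the scatter.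

The next compound, compound 4 `CCOC(=O)CNc1ccc(C/N=C(\S)NCc2ccc(C(C)(C)C)cc2)cc1F`, differs from compound 3 in one place: (ethoxycarbonyl)methyl in place of (methoxymethyl)carbonyl on a nitrogen on an aromatic ring. Both groups keep the same count of oxygen atoms and acceptors, with one more carbon in the entering group, and the anilino nitrogen itself is kept. Among the compounds with values here, no pair of measured compounds shows a change of this kind, so there is no measured step to lean on.

Since the rest of the molecule is unchanged, the step from compound 3 to compound 4 is expected to stay within the scatter, a 1.2-fold lower number from compound 3 to compound 4 (0.08 log units; within the scatter). Compound 4 is therefore estimated to give 9000 nM in this assay, with a plausible range from 3000 nM to 30000 nM.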

Compound 4, half-maximal inhibitory concentration: > 30000 nM
Compound 4 gave a limit, no number; the forecaster's own chance of this, stated with the estimate: 15%; middle value at least 3.3-fold (0.52 log units) from the limit.
By their numbers in this assay, from the lowest: compound 2; then compounds 1 and 3 (each within the scatter of the next). At a limit, above all of these: compound 4.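

In this assay, compound 4 gives only a limit, > 30000 nM, and not a number. Even so, replacing (methoxymethyl)carbonyl with (ethoxycarbonyl)methyl on a nitrogen on an aromatic ring gives an at least 2.7-fold higher number from compound 3 to compound 4 (0.43 log units; beyond the scatter), so the first measured step at this position shows that two groups with the same counts of donors and acceptors need not read alike, something the earlier compounds, with no step among them, could not show. The step gives only a minimum size, and how far it extends cannot be read from the limit: the limit of > 30000 nM in this assay, at which 1 of the 4 values shown sits.

The compounds shown leave open whether the loss follows the place of the carbonyl within the group on this nitrogen or the size of the entering group, as the two differ together between these compounds. They also leave open how this assay would read with a methyl ester, a carboxylic acid or a simple amine on this nitrogen, and whether the same change would give a similar step on the core of compound 2.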